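The compounds below may be only part of what the source reports. "The series", "measured", "known", "first", "only" and "open" are said of these compounds alone.

Measured so far in a functional assay on KB cells (Homo sapiens) for cytotoxicity, read by sulforhodamine B assay; on this read-out lower numbers stand for stronger inhibition and higher numbers for weaker inhibition:

compound 1, `C=C1[C@@H](OC(C)=O)C[C@@H]2[C@](C)(CO[Si](C)(C)C(C)(C)C)[C@H](OC(C)=O)CC[C@@]2(C)[C@@H]1C[C@@H](Nc1ccccc1F)C1=CCOC1=O`: 4740 nM
compound 2, `C=C1[C@@H](OC(C)=O)C[C@@H]2[C@](C)(CO[Si](C)(C)C(C)(C)C)[C@H](OC(C)=O)CC[C@@]2(C)[C@@H]1C[C@@H](Nc1ccc(OC)cc1)C1=CCOC1=O`: 5630 nM
compound 3, `C=C1[C@@H](OC(C)=O)C[C@@H]2[C@](C)(CO[Si](C)(C)C(C)(C)C)[C@H](OC(C)=O)CC[C@@]2(C)[C@@H]1C[C@@H](Nc1ccc(F)cc1)C1=CCOC1=O`: 5090 nM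

Compound 3 sits in the middle of the three numbers, with compound 1 nearest and compound 2 furthest, and neither gap reaches beyond the scatter, so the three read as one level in this assay. All three share the same core and differ only in the aryl group on the amine nitrogen.

Compound 4, `C=C1[C@@H](OC(C)=O)C[C@@H]2[C@](C)(CO[Si](C)(C)C(C)(C)C)[C@H](OC(C)=O)CC[C@@]2(C)[C@@H]1C[C@@H](Nc1cccc(OC)c1)C1=CCOC1=O`, is the next step from compound 3: 3-methoxyphenyl in place of 4-fluorophenyl on an amine nitrogen.

Going by the values given here, the steps that bear on it are the other aryl swaps on the same amine nitrogen: a 1.2-fold higher number from compound 1 to compound 2 (0.07 log units; within the scatter), a 1.1-fold higher number from compound 1 to compound 3 (0.03 log units; within the scatter) and a 1.1-fold lower number from compound 2 to compound 3 (0.04 log units; within the scatter). None of them leaves the scatter, and the methoxy group itself, on the 4-methoxyphenyl of compound 2, changed nothing beyond scatter. Among the compounds with values here, no step toward 3-methoxyphenyl has been measured, so the expectation rests on these three only. For compound 4 the expected step is a 1.0-fold higher number from compound 3 to compound 4 (0.01 log units; within the scatter), none beyond the scatter in either direction.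

Compound 4 is therefore estimated at 5200 nM in this assay, within 2600 nM to 10400 nM.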

Compound 4, half-maximal inhibitory concentration: 45200 nM
Estimate against measurement, compound 4: 8.7-fold (0.94 log units) below; measured number above the stated range.
By their numbers in this assay, from the lowest: compounds 1, 3 and 2 (each within the scatter of the next); then compound 4.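

In this assay, going by these compounds alone, the aryl group on the amine nitrogen turns out not to be indifferent: 3-methoxyphenyl gives an 8.9-fold higher number from compound 3 to compound 4 (0.95 log units; beyond the scatter) and a 9.5-fold higher number from compound 1 to compound 4 (0.98 log units; beyond the scatter), the first steps beyond the scatter. The sharpest reading comes from the pair that keeps the methoxy group and differs only as 4-methoxyphenyl against 3-methoxyphenyl, with an 8.0-fold higher number from compound 2 to compound 4 (0.90 log units; beyond the scatter), so the presence of a methoxy group alone does not set the level here. Nothing measured on these compounds accounts for the step.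

Still open, on these data alone, is whether ethoxy or hydroxyl in place of the methoxy of 3-methoxyphenyl keeps the number this high, and how plain phenyl reads on the same amine nitrogen. Also open, as far as these compounds go, is whether the step carries over to a core without the silyl ether.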